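The source may hold more compounds than are shown below. What is called first, only, known or untested is meant among the compounds shown, and "the series" means these compounds.

Measured compounds in the series:
- compound 1, `Oc1ccccc1CNc1ccc(-c2ccc(F)cc2)cc1`: 3860 nM
- compound 2, `Oc1ccccc1CNc1ccc(-c2ccc(-c3ccccc3)cc2)cc1`: "not active" (no number reported)

In a functional assay on Jurkat cells (Homo sapiens) for activation, with a stated time of 24 h (on this read-out higher numbers stand for an effect only at larger amounts of compound and lower numbers for an effect already at smaller amounts), compound 1 gives 3860 nM. In this assay, going by the values given here, compound 2 is recorded as "not active" (no number reported), so no single number stands for compound 2 on this read-out; it is the only entry of the pair without a numeric value. Among the compounds with values here, no step between measured compounds is available here, and the difference between compound 1 and compound 2 is stated by the two entries alone.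

Compound 3, `N#Cc1ccc(-c2ccc(NCc3ccccc3O)cc2)cc1`, is not yet measured. It differs from compound 2 in one place: cyano in place of phenyl on an aromatic carbon. Since compound 2 has no number, the size of the step cannot be computed from the data; compound 1 carries a small substituent at the corresponding position and has a measured value, so compound 3 is expected to land in a comparable region and to give a number rather than another blank. For compound 3 the expected value in this assay is 5000 nM, estimated within 1500 nM to 20000 nM.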

Compound 3, half-maximal effective concentration: "not active" (no number reported)
No number was reported for compound 3; there is nothing to compare the estimate with.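

Compound 2 and compound 3 are both recorded as "not active" in this assay, so no step can be read between them. The compounds shown leave open which other groups on that aromatic carbon would give a number, as compound 1 does at 3860 nM. No available evidence bears on this result.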